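Larger ketone on a shared core: cytotoxicity outlook

The compounds below may be only part of what the source reports. "The series", "measured", "known", "first", "only" and "open" are said of these compounds alone.

Compound 3 `CC(=O)c1ccn(-c2ccc3c(c2)B(O)OC3)c1` carries an acetyl group on an aromatic carbon. In an ADME assay on L929 cells (Mus musculus) for cytotoxicity, read by resazurin assay, with a stated time of 72 h (a higher number here means a weaker inhibitor, a lower number a stronger inhibitor), compound 3 gives > 10 ug/mL, which is a limit of the assay rather than a number. Compound 1 `OB1OCc2ccc(-n3cccc3)cc21` in this assay gives > 10 ug/mL, also a limit. Compound 2 `OB1OCc2ccc(-n3cccc3Sc3ccccc3Cl)cc21` gives > 10 ug/mL, again a limit. The step that the two limits leave unreadable from compound 1 to compound 3 cannot be read because both of its values sit at the limit of > 10 ug/mL in this assay, at which 3 of the 3 values shown sit. Compound 4 `O=C(c1ccn(-c2ccc3c(c2)B(O)OC3)c1)c1ccc(Cl)cc1Cl` differs from compound 3 by 2,4-dichlorophenyl in place of methyl on a carbonyl carbon. Among the compounds with values here, no measured step bears on this change, and every measurement so far stops at the limit, so neither size nor direction can be taken from them. Compound 4 is expected to give 12 ug/mL, within a range of 4 ug/mL to 40 ug/mL. This estimate corresponds to an expected step that the limit leaves unreadable from compound 3 to compound 4.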

Compound 4, half-maximal inhibitory concentration: > 10 ug/mL
Compound 4 ended at the assay's limit; the forecaster's own chance of this, stated with the estimate: 55%; the middle value lies beyond the limit too.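

Compound 3 and compound 4 both stop at a limit of this assay, so no step between them can be read: the limit of > 10 ug/mL in this assay, at which 4 of the 4 values shown sit.

The compounds shown leave open whether 2,4-dichlorophenyl in place of methyl changes cytotoxicity at all, and how the four compounds rank against each other.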